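Sulfonyl aryl variation in a benzylamide sulfonamide series

The source may report more compounds than this note shows. Statements on the series, on what has been measured and on what is new or still open speak of the compounds shown alone.

The three measured compounds share one core and differ at the group on the sulfonyl sulfur and at the amide end. In an assay on MDA-MB-231 cells for displacement of a labelled ligand from C-X-C chemokine receptor type 4 (Homo sapiens), read by fluorescence and microscopy, with stated times of 10 min and 30 min (a higher number here means that more compound is needed for the effect, a lower number that less compound is needed), compound 1 `COc1ccccc1C(=O)NCc1ccc(CNS(=O)(=O)c2ccc([N+](=O)[O-])cc2)cc1` gives 100 nM. Compound 2 `O=C(NCc1ccc(CNS(=O)(=O)c2ccccc2F)cc1)c1cccnc1` gives 100 nM in this assay. Compound 3 `Cc1ccccc1C(=O)NCc1ccc(CNS(=O)(=O)c2cccc(Cl)c2)cc1` gives 100 nM in this assay. Compound 3 thus stands level with compound 1 and compound 2 at the digits shown; its nearest neighbour on the numbers is compound 1 and its furthest is compound 2, and neither gap goes beyond the scatter. Among the compounds with values here, no two measured compounds differ in only one place, so no single step can be read from them.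

Compound 4 `Cc1ccccc1C(=O)NCc1ccc(CNS(=O)(=O)c2ccccc2Cl)cc1` has not been measured in this assay. It differs from compound 3 in one place (2-chlorophenyl in place of 3-chlorophenyl on a sulfonyl sulfur); the two have the same atoms, joined differently, with 2-chlorophenyl in place of 3-chlorophenyl on a sulfonyl sulfur. Across the three measured compounds the group on the sulfonyl sulfur varies while the reading stays level, so the step to compound 4 is expected to be none beyond the scatter, in either direction. For compound 4 the expected value in this assay is 100 nM, with a range from 50 nM to 200 nM. This corresponds to an expected step of no change at the digits printed from compound 3 to compound 4 (within the scatter).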

Compound 4, effective concentration (reported as EC, without a stated level of effect): 1000 nM
The estimate for compound 4 lay 10-fold (1.00 log units) below the measured number; measured number outside the range, above it.
By their numbers in this assay, from the lowest: compounds 1, 2 and 3 (each within the scatter of the next); then compound 4.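

With 2-chlorophenyl in place of 3-chlorophenyl on a sulfonyl sulfur, this assay shows a 10-fold higher number from compound 3 to compound 4 (1.00 log units; beyond the scatter), even though the two groups have the same heavy atoms and the same counts of hydrogen-bond donors and acceptors. The reading at this position therefore depends on where the chlorine sits on the phenyl ring, not only on which atoms the group contains, a sensitivity that the level readings of compounds 1, 2 and 3 could not reveal, as those compounds differ from one another in more than one place. No measurement available here accounts for the size of this step.

On these data alone, it remains open whether the same change would give a step of similar size with another group at the amide end, since the step rests on a single pair of compounds. Also open, as far as these compounds go, is how a bromophenyl or a trifluoromethyl group on the sulfonyl sulfur would read against the 3-chlorophenyl and 2-chlorophenyl groups.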